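Chain lengthening on the ring nitrogen across two amide cores

The source may hold more compounds than are shown below. What is called first, only, known or untested is meant among the compounds shown, and "the series" means these compounds.

Working notes on a small set read in a functional assay on a cell-free system (Platelet, plasma, Homo sapiens) for inhibition; a lower number here means a stronger inhibitor, a higher number a weaker inhibitor. Compound 1 `O=C(O)CN1Cc2ccc(NC(=O)CCCC3CCNCC3)cc2C1=O` gives 66000 nM in this assay. Compound 2 `O=C(O)CCCN1Cc2ccc(NC(=O)CCCC3CCNCC3)cc2C1=O` gives 51000 nM. The change between them is 2-carboxyethyl in place of carboxy on a saturated chain carbon bound to an amide-type nitrogen in a ring and it produced a 1.3-fold lower number from compound 1 to compound 2 (0.11 log units; within the scatter).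

Compound 3 `O=C(O)CN1Cc2ccc(NC(=O)c3ccc(C4CCNCC4)cc3)cc2C1=O` carries a different amide part; the difference between its core and the core of compound 1 is not broken down here. In this assay compound 3 gives 24000 nM, the lowest of the three numbers, with compound 2 and compound 1 both lying beyond the scatter from it.

Compound 4 `O=C(O)CCCN1Cc2ccc(NC(=O)c3ccc(C4CCNCC4)cc3)cc2C1=O` is not yet measured. It differs from compound 3 by 2-carboxyethyl in place of carboxy on a saturated chain carbon bound to an amide-type nitrogen in a ring. Going by the values given here, this is the same change, at the same place, as the one from compound 1 to compound 2, so the one measured instance is the only guide. Because that instance gave a 1.3-fold lower number from compound 1 to compound 2 (0.11 log units; within the scatter), a step within the scatter, the step from compound 3 to compound 4 is expected to be small as well, estimated at a 1.3-fold lower number from compound 3 to compound 4 (0.10 log units; within the scatter). That the precedent sits on a different core widens the uncertainty, but the direction of the precedent is the only indication available. Compound 4 is therefore expected to give about 19000 nM in this assay, with an estimated range from 8000 nM to 45000 nM.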

Compound 4, half-maximal inhibitory concentration: 410000 nM
Beside the measured number, compound 4's estimate is 22-fold (1.33 log units) below it; measured number above the stated range.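

In this assay, replacing carboxy with 2-carboxyethyl on a saturated chain carbon bound to an amide-type nitrogen in a ring (equivalently, carboxymethyl to 3-carboxypropyl) gives a 17-fold higher number from compound 3 to compound 4 (1.23 log units; beyond the scatter), a large loss of inhibition on this core. The same change therefore does not carry over unchanged from the core of compound 1 to the core of compound 3: the same change on two cores in this assay, a 1.3-fold lower number (0.11 log units; within the scatter) from compound 1 to compound 2 and a 17-fold higher number (1.23 log units; beyond the scatter) from compound 3 to compound 4, 22-fold (1.34 log units) apart, beyond the scatter of two such steps. This shows that the result of the change depends on the amide part in these two pairs, so the step on one core is a poor guide to the step on the other, but with one pair per core it gives no general rule for the series and does not show which feature of the amide part is responsible.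

The compounds shown hold only the carboxymethyl and 3-carboxypropyl chains, which leaves open whether the loss on the core of compound 3 builds gradually or appears abruptly with a chain of intermediate length ending in a carboxylic acid. Also open, as far as these compounds go, is whether an ester or a primary amide in place of the carboxylic acid would show the same difference between the two cores.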